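The compounds below may be only part of what the source reports. "The series", "measured", "known", "first", "only" and "open" are said of these compounds alone.

Measured so far in a functional assay on HeLa cells (Homo sapiens) for cytotoxicity, read by sulforhodamine B assay, with a stated time of 48 h; on this read-out lower numbers stand for stronger inhibition and higher numbers for weaker inhibition:
- compound 1 `COc1ccc(/C=C2\C(=O)N(Cc3cn([C@@H]4O[C@H](COC(C)=O)[C@@H](OC(C)=O)[C@H](OC(C)=O)[C@H]4OC(C)=O)nn3)c3ccccc32)cc1OC` gives 63400 nM in this assay.
- compound 2 `CC(=O)OC[C@H]1O[C@@H](n2cc(CN3C(=O)/C(=C/c4ccc(N(C)C)cc4)c4ccccc43)nn2)[C@H](OC(C)=O)[C@@H](OC(C)=O)[C@@H]1OC(C)=O` gives 26300 nM in this assay.

On these two numbers compound 1 stands highest, that is weakest; compound 2 lies lower by a margin beyond the usual scatter, so the two are distinguishable. Among the compounds with values here, both, however, sit in the range of weak cytotoxicity, and no step between the two is worked out here, since the structures differ in more than one place.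

The next compound in the series is compound 3 `CC(=O)OC[C@H]1O[C@@H](n2cc(CN3C(=O)/C(=C\c4cccs4)c4ccccc43)nn2)[C@H](OC(C)=O)[C@@H](OC(C)=O)[C@@H]1OC(C)=O`. Relative to compound 1 the change is thiophen-2-yl in place of 3,4-dimethoxyphenyl on a double-bonded chain carbon bound to a double-bonded ring carbon. Within the data shown here, no measured pair covers this change, so the expectation has to rest on the two values at hand, which show only that the core tolerates variation at this position without leaving the weak range. For compound 3 a small step is expected in this assay, estimated as a 1.4-fold lower number from compound 1 to compound 3 (0.15 log units; within the scatter), with no firm direction and most likely within or close to the scatter. Compound 3 is therefore expected to give about 45000 nM in this assay, between 15000 nM and 130000 nM.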

Compound 3, half-maximal inhibitory concentration: > 100000 nM
Compound 3: a limit, no number; the forecaster's own chance of this, stated with the estimate: 15%; at least 2.2-fold (0.34 log units) between middle value and limit.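

In this assay, compound 3 gives > 100000 nM, which is a limit of the assay and not a number. Thiophen-2-yl in place of 3,4-dimethoxyphenyl on a double-bonded chain carbon bound to a double-bonded ring carbon gives an at least 1.5-fold higher number from compound 1 to compound 3 (0.19 log units; that floor lies within the scatter), so this change brings no measurable gain in cytotoxicity, although the floor alone does not separate the two compounds beyond the scatter. Compounds 1 and 2 showed this position only with values inside the measured range, whereas with compound 3 the position also carries a group that leaves that range, and the true size of the step cannot be read: the limit of > 100000 nM in this assay, at which 1 of the 3 values shown sits.

The compounds shown leave open whether the outcome follows from removing the methoxy groups or from replacing the phenyl ring with thiophene. A plain phenyl or a 4-methoxyphenyl at this place would separate those two readings, and a carboxylic acid or a primary amine on the ring would test a different kind of substituent here.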